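Inhibition Level Across Three Thiophene Ketones

The source may report more compounds than this note shows. Statements on the series, on what has been measured and on what is new or still open speak of the compounds shown alone.

Measured compounds:
compound 1 `Cc1ccc(C(=O)c2c(CC(C)(C)C)csc2N)cc1` gives 1%
compound 2 `CC(C)(C)Cc1c(Br)sc(N)c1C(=O)c1ccc(Cl)cc1` gives 1%
compound 3 `CC(C)(C)Cc1c(Br)sc(N)c1C(=O)c1cccc(Cl)c1` gives 1%

Compound 3 was tested in an assay on CHO cells for displacement of a labelled ligand from adenosine receptor A3 (Homo sapiens), read by scintillation counting, tested at 10 uM (on this read-out higher numbers stand for more inhibition at the one concentration tested (going by the name of the read-out) and lower numbers for less inhibition), and, as shown above, stands level with compound 1 and compound 2 at the digits reported. Within the data shown here, the one step among the measured compounds that touches the same position, no change at the digits printed from compound 2 to compound 3 (within the scatter), was flat within the scatter.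

The next compound, compound 4 `Cc1ccc(C(=O)c2c(N)sc(Br)c2CC(C)(C)C)cc1`, differs from compound 3 in a single place: 4-methylphenyl in place of 3-chlorophenyl on a carbonyl carbon. Compound 1 carries the same 4-methylphenyl group on its carbonyl carbon and gives 1% in this assay, so the group entering in compound 4 has already appeared with inhibition level with the other measured compounds. Swapping aryl groups on this carbon has so far moved nothing, and there is no reason in these data to expect otherwise.

Compound 4 is therefore expected to show a step of a number 1 percentage points higher from compound 3 to compound 4 (within the scatter), that is, no change beyond the scatter. The estimated value for compound 4 is 2%, with a range from -8% to 12%.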

Compound 4, a percentage reported as inhibition, at one concentration (the size of the read-out at that concentration, not a potency): 1%
Estimate against measurement, compound 4: 1 percentage points above; measured number inside the range.
By their numbers in this assay, from the lowest: compounds 1, 2, 3 and 4 (each within the scatter of the next).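

With the 4-methylphenyl group now on the bromo-bearing core, this assay shows no change at the digits printed from compound 3 to compound 4 (within the scatter) for this exchange on the carbonyl carbon, and methyl in place of chloro on an aromatic carbon gives no change at the digits printed from compound 2 to compound 4 (within the scatter) in the same series. Among these compounds, the bromo group can now be read on its own for the first time, since bromo in place of hydrogen on an aromatic carbon gives no change at the digits printed from compound 1 to compound 4 (within the scatter) with the 4-methylphenyl group held fixed. No independent data are available to explain this flat result.

All four compounds sit level at a very low reading, so these steps cannot show whether either position matters once a compound registers real inhibition. Open too, going by these compounds, is whether an amine or a carboxylic acid on the phenyl ring, or a longer chain in place of the bromo group, would lift the reading at all.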